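From a Chlorophenyl to a Bromophenyl Group on the Carbonyl

The source may report more compounds than this note shows. Statements on the series, on what has been measured and on what is new or still open speak of the compounds shown alone.

Compound 2 `O=C(/C=C/C1=Cc2ccccc2OC1)c1cccc(Cl)c1` gives 51% in a functional assay on the whole organism for inhibition, with Mus musculus as the target, with a stated time of 1 h, at a dose of 30 mg/kg by the intraperitoneal route (a higher number here means more inhibition at the dose given (going by the name of the read-out), a lower number less inhibition), the lowest of the two numbers measured, while compound 1 `O=C(/C=C/C1=Cc2ccccc2OC1)c1cccc(F)c1` stands nearest at 52.4%, within the scatter. Compound 3 `O=C(/C=C/C1=Cc2ccccc2OC1)c1ccc(Br)cc1` differs from compound 2 by 4-bromophenyl in place of 3-chlorophenyl on a carbonyl carbon. Among the measured compounds shown here, the one measured step, a number 1.4 percentage points lower from compound 1 to compound 2 (within the scatter), is also a halogen exchange on an aromatic carbon and so bears on this change, although compound 3 goes from a 3-chlorophenyl to a 4-bromophenyl group rather than keeping the same group pattern. Compound 3 is therefore expected to show a step of about a number 1 percentage points lower from compound 2 to compound 3 (within the scatter), nothing beyond the scatter, with an estimated 50%, ranging from 35% to 65%.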

Compound 3, a percentage reported as inhibition, in the whole organism at one dose (the size of the read-out at that dose, not a potency): 66%
Estimate against measurement, compound 3: 16 percentage points below; measured number above the stated range.
By their numbers in this assay, from the lowest: compounds 2 and 1 (each within the scatter of the next); then compound 3.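

In this assay the group on the carbonyl carbon proves able to move the number beyond the scatter, which the exchange of fluoro for chloro did not: 4-bromophenyl in place of 3-chlorophenyl gives a clear step (a number 15 percentage points higher from compound 2 to compound 3 (beyond the scatter)), and 4-bromophenyl in place of 3-fluorophenyl gives another (a number 13.6 percentage points higher from compound 1 to compound 3 (beyond the scatter)). Both steps change the halogen and its ring position together, so the two cannot be told apart. No evidence is available that accounts for this rise. Still open, on these data alone, is whether bromine or its place carries the step, and whether a methoxy group or an amine on that phenyl ring would keep it.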